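A few compounds are considered here, and "the series" means these few. Any claim that something is new, unique, unknown or untested is made for them only; others in the source may bear on it.

The compounds measured so far, with their values in a functional assay on MCF7 cells (Homo sapiens) for inhibition, read by MTT assay, with a stated time of 72 h; on this read-out lower numbers stand for stronger inhibition and higher numbers for weaker inhibition:

Compound 1 `Cc1ccc2c(c1)/C(=N/NC(=S)N1CCN(c3ccccc3)CC1)C(=O)N2` gives 14900 nM.
Compound 2 `O=C1Nc2ccc(Cl)cc2/C1=N/NC(=S)N1CCN(c2ccccc2)CC1` gives 10400 nM.
Compound 3 `O=C1Nc2cccc(Br)c2/C1=N/NC(=S)N1CCN(c2ccccc2)CC1` gives 40700 nM.

Compound 2 has the lowest of the three numbers in this assay. Its nearest neighbour is compound 1, whose number is higher but within the scatter, so the two cannot be set in order; compound 3 stands furthest away, beyond the scatter. Among the measured compounds shown here, the one single-point step among the measured compounds, a 1.4-fold lower number from compound 1 to compound 2 (0.16 log units; within the scatter), is small.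

Compound 4 `O=C1Nc2ccc(Cl)cc2/C1=N/NC(=S)N1CCN(c2ccccc2[N+](=O)[O-])CC1` differs from compound 2 in one place: nitro in place of hydrogen on an aromatic carbon. Cut one bond further out, the change reads phenyl to 2-nitrophenyl. For the measured compounds named here, no measured step touches this part of the shared core: the only step seen, from compound 1 to compound 2, changes the other aromatic ring, and it stays within the scatter. There is therefore no basis in these data for expecting a step beyond the scatter in this assay in either direction; the number for compound 4 is estimated to lie close to that of compound 2, with a wide range to cover the lack of a matching precedent. The expected step is a 1.0-fold lower number from compound 2 to compound 4 (0.02 log units; within the scatter). Compound 4 is thus estimated at 10000 nM, between 4000 nM and 26000 nM.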

Compound 4, half-maximal inhibitory concentration: 7490 nM
For compound 4 the middle estimate is 1.3-fold (0.13 log units) above the measured one, within the range that was stated.
By their numbers in this assay, from the lowest: compounds 4, 2 and 1 (each within the scatter of the next); then compound 3.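

In this assay, among the compounds shown here, the change from phenyl to 2-nitrophenyl gives a 1.4-fold lower number from compound 2 to compound 4 (0.14 log units; within the scatter) and so offers the first reading on this part of the shared core, a step that cannot be told apart from repeated measurement. Nitro, with its 3 heavy atoms, can therefore stand on this aromatic carbon, ortho to a large group, without a change that can be read in this assay, and compound 2 and compound 4 cannot be set in order. No measurement shown here accounts for this result.

The compounds shown carry only one group on this phenyl, so it remains open how an amine, a carboxylic acid or a methoxy group would read at the same place, and how nitro would read on another carbon of that ring. From the compounds shown here alone, it also remains open whether the nitro change would give a similar step if the chloro of compound 2 were replaced by the methyl of compound 1 or if the ring carried bromo as in compound 3.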